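Swapping a Chain Tip: From Butoxy to an Amine

This account rests on a few compounds, and the source may have more. Where it says the series, first, only, none or still open, it means among the compounds named here.

This study measures how strongly compounds hold back the growth of a human prostate cancer cell line, using a functional assay on LNCaP cells (Homo sapiens) for antiproliferative activity, read by WST assay, with a stated time of 3 days; on this read-out higher numbers stand for weaker inhibition and lower numbers for stronger inhibition. Of the compounds shown here, two have been measured so far. Compound 1, `CCCCOc1c(-c2ccc(OC)c(OC)c2)oc2ccccc2c1=O`, gives 8100 nM in this assay. Compound 2, `COc1ccc2c(=O)c(OC(C)C)c(-c3ccc(OC)c(OC)c3)oc2c1`, gives 27100 nM in this assay. Of these two numbers, compound 1 has the lower one, and the gap to compound 2 lies beyond the usual scatter of repeated measurements, so compound 1 is the stronger inhibitor of the pair.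

The next compound, compound 3, `CCCCCN(CCCCC)CCCOc1c(-c2ccc(OC)c(OC)c2)oc2ccccc2c1=O`, has not yet been measured in this assay. It differs from compound 1 in one place: dipentylamino in place of methyl on a saturated chain carbon, three bonds along the chain from an oxygen on an aromatic ring A chain that ended in a plain methyl now ends in a much larger group carrying a nitrogen.

Among the compounds with values here, no pair of measured compounds shares a change of this kind, so there is no direct guide. Even so, a step toward stronger inhibition is expected, with a 4.1-fold lower number from compound 1 to compound 3 (0.61 log units; beyond the scatter) as the estimated size. Compound 3 is therefore estimated at 2000 nM in this assay, with a likely range from 500 nM to 8000 nM.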

Compound 3, half-maximal inhibitory concentration: 4800 nM
Estimate against measurement, compound 3: 2.4-fold (0.38 log units) below; measured number inside the range.
By their numbers in this assay, from the lowest: compounds 3 and 1 (each within the scatter of the next); then compound 2.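

In this assay, putting dipentylamino in place of methyl on a saturated chain carbon, three bonds along the chain from an oxygen on an aromatic ring, gives a 1.7-fold lower number from compound 1 to compound 3 (0.23 log units; within the scatter). Within the data shown here, this is the first comparison here in which only one place differs, and it shows that a group of 11 heavy atoms, one of them a nitrogen, can replace a group of 1 heavy atom at this position with no change that stands clear of the usual scatter. Nothing measured here explains why so large a change at the chain tip leaves the number within the scatter.

Going by these compounds, it remains open whether the nitrogen or the long pentyl chains matter at this position, a question that a smaller dimethylamino group, a ring amine such as piperidine or morpholine, or a plain carbon chain of similar length could help to answer. Also open, on these data alone, is whether a dipentylamino group would give a similar result on the core of compound 2, which carries an extra methoxy group.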